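This account rests on a few compounds, and the source may have more. Where it says the series, first, only, none or still open, it means among the compounds named here.

Compound 1 `N#Cc1ccc(N2CCCc3c(-c4cccnc4)cccc32)cc1C(F)(F)F`: 12300 nM
Compound 2 `CCN(c1ccc(C#N)c(Cl)c1)c1cc(-n2cnc3ccccc32)ccc1C`: 3040 nM

In a functional assay on CWR22R cells (Homo sapiens) for antiproliferative activity, read by CCK-8 assay, with a stated time of 6 days (a lower number here means a stronger inhibitor, a higher number a weaker inhibitor), compound 1 gives 12300 nM, the higher of the two numbers and so the weaker result. Compound 2 gives 3040 nM, a lower number by more than the usual scatter of repeat measurements. The two compounds differ in more than one place, so this gap says nothing about any single group.

Compound 3 `Cn1nccc1-c1cccc2c1CCCN2c1ccc(C#N)c(C(F)(F)F)c1` keeps the core of compound 1 and changes one group: 1-methyl-1H-pyrazol-5-yl in place of pyridin-3-yl on an aromatic carbon. In words, 1-methyl-1H-pyrazol-5-yl stands in place of pyridin-3-yl on an aromatic carbon. Going by the values given here, no measured pair shows what this swap does, so only a small move towards a lower number in this assay is expected, probably within the scatter. The expected change is a 1.5-fold lower number from compound 1 to compound 3 (0.19 log units; within the scatter). The estimated value for compound 3 is 8000 nM, with an expected range of 2500 nM to 25000 nM.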

Compound 3, half-maximal inhibitory concentration: 10400 nM
For compound 3 the middle estimate is 1.3-fold (0.11 log units) below the measured one; the range from low to high includes it.
By their numbers in this assay, from the lowest: compound 2; then compounds 3 and 1 (each within the scatter of the next).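

In this assay, putting 1-methyl-1H-pyrazol-5-yl in place of pyridin-3-yl on this aromatic carbon gives a 1.2-fold lower number from compound 1 to compound 3 (0.07 log units; within the scatter), so the two compounds cannot be told apart. Going by these compounds alone, this is the first direct reading at this position: a five-membered aromatic ring with 2 hetero atoms stands in for a six-membered aromatic ring with 1 hetero atom, and the number stays within the scatter. Nothing available here explains this result.

Both rings shown at this carbon are aromatic and contain nitrogen, so it remains open whether a plain phenyl ring, a morpholine ring or an amine would shift the number beyond the scatter. As far as these compounds go, it also remains open whether any group at this position could bring the core of compound 1 to a clearly lower number.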